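This account rests on a few compounds, and the source may have more. Where it says the series, first, only, none or still open, it means among the compounds named here.

Compound 1 `Cc1csc(N/C(S)=N/[C@@H](C)c2cccc3ccccc23)n1` sits at the weak end of the two measured compounds: in a functional assay on RBL-2H3 cells (Rattus norvegicus) for inhibition (on this read-out higher numbers stand for weaker inhibition and lower numbers for stronger inhibition), compound 1 gives 83200 nM, the highest number of the pair, while compound 2 `C[C@@H](/N=C(\S)Nc1nc2ccccc2s1)c1cccc2ccccc12` gives 18900 nM in this assay, a step that lies beyond the scatter. Compound 3 `Cc1ccc(N/C(S)=N/[C@@H](C)c2cccc3ccccc23)nc1` has not been measured; it differs from compound 1 in one place (5-methylpyridin-2-yl in place of 4-methyl-1,3-thiazol-2-yl on an amine nitrogen). Both the group that leaves and the group that enters carry a methyl on an aromatic ring, and the larger change seen between compound 1 and compound 2 gives no direct guide to this exchange. Within the data shown here, no step between measured compounds isolates it, so the expectation for compound 3 rests on compound 1 alone. A small shift toward stronger inhibition is expected, but one that may still fall within the scatter, with an estimated step of a 1.4-fold lower number from compound 1 to compound 3 (0.14 log units; within the scatter). Compound 3 is therefore estimated at 60000 nM in this assay, within a range of 20000 nM to 200000 nM.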

Compound 3, half-maximal inhibitory concentration: > 100000 nM
Compound 3: no number, only a limit; the forecaster's own chance of this, stated with the estimate: 15%; at least 1.6-fold (0.22 log units) between middle value and limit.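

The value for compound 3 is a limit of the assay and not a number: the limit of > 100000 nM in this assay, at which 1 of the 3 values shown sits. In this assay, putting 5-methylpyridin-2-yl in place of 4-methyl-1,3-thiazol-2-yl on the amine nitrogen gives an at least 1.2-fold higher number from compound 1 to compound 3 (0.07 log units; that floor lies within the scatter). This exchange therefore brings no sign of stronger inhibition at this position, which compounds measured earlier could not show, although the data fix only the direction that remains possible and not the size of the change.

On these data alone, how far compound 3 lies past its limit cannot be read, so the true size of this step stays unknown. The compounds shown also leave open whether a plain pyridin-2-yl, a phenyl ring or a methoxy group in place of the methyl on the pyridine would give a measurable number in this assay.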